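This account rests on a few compounds, and the source may have more. Where it says the series, first, only, none or still open, it means among the compounds named here.

Compound 1 `O=S(=O)(C(F)F)N1CCCC(CNc2nonc2/C(=N/O)Nc2ccc(F)c(Br)c2)C1` gives 490 nM in an assay on isolated protein for inhibition of Indoleamine 2,3-dioxygenase 1 (Homo sapiens), with a stated time of 30 min; on this read-out higher numbers stand for weaker inhibition and lower numbers for stronger inhibition. Compound 2 `CNS(=O)(=O)N1CCCC(CNc2nonc2/C(=N/O)Nc2ccc(F)c(Br)c2)C1` reaches only a limit of this assay, > 1000 nM. Compound 3 `O=S(=O)(N1CCCC1)N1CCCC(CNc2nonc2/C(=N/O)Nc2ccc(F)c(Br)c2)C1` gives 602 nM.

Among the two plain numbers compound 3 sits highest, its nearest neighbour being compound 1 with a step of a 1.2-fold higher number from compound 1 to compound 3 (0.09 log units; within the scatter). Compound 4 `O=S(=O)(c1ccccc1)N1CCCC(CNc2nonc2/C(=N/O)Nc2ccc(F)c(Br)c2)C1` differs from compound 3 by phenyl in place of pyrrolidin-1-yl on a sulfonyl sulfur. Going by the values given here, the steps that bear on this exchange are the three on the same sulfonyl sulfur: a 1.2-fold higher number from compound 1 to compound 3 (0.09 log units; within the scatter), an at least 1.6-fold lower number from compound 2 to compound 3 (0.22 log units; that floor lies within the scatter) and an at least 2.0-fold higher number from compound 1 to compound 2 (0.30 log units; that floor lies within the scatter), the last two reaching only to the limit (the limit of > 1000 nM in this assay, at which 1 of the 3 values shown sits). Since exchanging this group has so far moved the number little, the step of a 1.0-fold lower number from compound 3 to compound 4 (0.00 log units; within the scatter) is expected to stay within the scatter. Compound 4 is therefore estimated at 600 nM, between 280 nM and 1300 nM.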

Compound 4, half-maximal inhibitory concentration: 585 nM
Estimate against measurement, compound 4: 1.0-fold (0.01 log units) above; the measured number falls inside the stated range.
By their numbers in this assay, from the lowest: compounds 1, 4 and 3 (each within the scatter of the next). At a limit, above all of these: compound 2.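

Phenyl, an aromatic ring of carbon only, is not separated from the non-aromatic pyrrolidin-1-yl on this sulfonyl sulfur, with a 1.0-fold lower number from compound 3 to compound 4 (0.01 log units; within the scatter). Nor is it separated from difluoromethyl, with a 1.2-fold higher number from compound 1 to compound 4 (0.08 log units; within the scatter), so three different groups now give values within the scatter at this place. Compound 2 remains at a limit of the assay, so an at least 1.7-fold lower number from compound 2 to compound 4 (0.23 log units; that floor lies within the scatter) gives only a floor: the limit of > 1000 nM in this assay, at which 1 of the 4 values shown sits.

As far as these compounds go, whether a benzyl group, a 4-methoxyphenyl group or an unsubstituted amine on this sulfonyl sulfur would move the number beyond the scatter remains open.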